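The compounds below may be only part of what the source reports. "The series", "measured", "known", "first", "only" and "open" are said of these compounds alone.

Compound 1 `Oc1cccc(-c2cc(-c3ccoc3)cc(-c3ccccc3O)n2)c1` was tested in a functional assay on T47D cells (Homo sapiens) for cytotoxicity, read by CCK-8 assay; on this read-out lower numbers stand for stronger inhibition and higher numbers for weaker inhibition. In this assay compound 1 gives only a limit, > 50000 nM. Compound 2 `Oc1ccc(-c2cc(-c3ccoc3)cc(-c3ccccc3O)n2)cc1` likewise gives only a limit in this assay, > 50000 nM. The two differ by 4-hydroxyphenyl in place of 3-hydroxyphenyl on an aromatic carbon, and the step that the two limits leave unreadable from compound 1 to compound 2 cannot be sized, since (the limit of > 50000 nM in this assay, at which 2 of the 3 values shown sit). Compound 3 `Oc1cccc(-c2cc(-c3ccccn3)cc(-c3cccc(O)c3)n2)c1` gives 1410 nM in this assay; how its core differs from that of compound 1 is not broken down here. Compound 4 `Oc1ccc(-c2cc(-c3ccccn3)cc(-c3cccc(O)c3)n2)cc1` is not yet measured; it differs from compound 3 by 4-hydroxyphenyl in place of 3-hydroxyphenyl on an aromatic carbon. This is the same kind of change as from compound 1 to compound 2, though the surroundings differ: there the place was meta to a 2-hydroxyphenyl group and a furan-3-yl group, here it is meta to a 3-hydroxyphenyl group and a pyridin-2-yl group. Since the earlier step that the two limits leave unreadable from compound 1 to compound 2 gives no readable size, the expected step of a 1.4-fold higher number from compound 3 to compound 4 (0.15 log units; within the scatter) is kept small, within the usual scatter. Compound 4 is thus estimated at 2000 nM, with a range from 600 nM to 9000 nM.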

Compound 4, half-maximal inhibitory concentration: 980 nM
Estimate against measurement, compound 4: 2.0-fold (0.31 log units) above, within the range that was stated.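

In this assay, putting 4-hydroxyphenyl in place of 3-hydroxyphenyl gives a 1.4-fold lower number from compound 3 to compound 4 (0.16 log units; within the scatter), so on this core the two groups cannot be told apart. The same change on the core of compound 1 cannot be read, since compound 1 and compound 2 each give only a limit of the assay, not a number: the limit of > 50000 nM in this assay, at which 2 of the 4 values shown sit. This leaves a single readable pair, which describes one core and does not show that the change behaves the same way on another.

As far as these compounds go, what an amine or a carboxylic acid in place of the hydroxy group on that ring would give stays open. Also open, from the compounds shown here alone, is how the change would behave on a core where both compounds give numbers.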